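The source may report more compounds than this note shows. Statements on the series, on what has been measured and on what is new or still open speak of the compounds shown alone.

The measured compounds in an ADME assay on MT4 cells (Homo sapiens) for cytotoxicity, read by MTT assay (on this read-out lower numbers stand for higher toxicity in this test and higher numbers for lower toxicity in this test), stand as follows: compound 1 `Cc1ccc(NC(=O)CSc2nccn2-c2cccc3ccccc23)c(Br)c1` gives 29400 nM; compound 2 `O=C(CSc1nccn1-c1cccc2ccccc12)Nc1ccccc1[N+](=O)[O-]` gives 28800 nM; compound 3 `COc1ccc(-n2ccnc2SCC(=O)Nc2ccc(C)cc2Br)cc1` gives 25800 nM.

Compound 1 and compound 2 differ in one place, (2-nitrophenyl in place of 2-bromo-4-methylphenyl on an amide-type nitrogen), and this change made the step of a 1.0-fold lower number from compound 1 to compound 2 (0.01 log units; within the scatter). Compound 3 carries a different core from compound 1; how the two cores differ is not broken down here, and the two values of these compounds show only a gap within the scatter.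

Compound 4 `COc1ccc(-n2ccnc2SCC(=O)Nc2ccccc2[N+](=O)[O-])cc1` has not yet been measured in this assay. It stands to compound 3 as compound 2 stands to compound 1, namely (2-nitrophenyl in place of 2-bromo-4-methylphenyl on an amide-type nitrogen), the same change at the same kind of place. Since the step from compound 1 to compound 2 was a 1.0-fold lower number from compound 1 to compound 2 (0.01 log units; within the scatter), the same change on the core of compound 3 is expected to give a step of about a 1.0-fold lower number from compound 3 to compound 4 (0.01 log units; within the scatter), resting on that single precedent. Compound 4 is therefore estimated at 25000 nM in this assay, with a likely range from 12000 nM to 50000 nM.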

Compound 4, half-maximal cytotoxic concentration: 161000 nM
Beside the measured number, compound 4's estimate is 6.4-fold (0.81 log units) below it, and the stated range ends below it.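

In this assay, putting 2-nitrophenyl in place of 2-bromo-4-methylphenyl on the amide-type nitrogen gave a 6.2-fold higher number from compound 3 to compound 4 (0.80 log units; beyond the scatter), so on the core of compound 3 the change moved the number towards lower toxicity in this test. Set beside the earlier case, the same change did not carry over from one core to the other with the same size: the same change on two cores in this assay, a 1.0-fold lower number (0.01 log units; within the scatter) from compound 1 to compound 2 and a 6.2-fold higher number (0.80 log units; beyond the scatter) from compound 3 to compound 4, 6.4-fold (0.80 log units) apart, beyond the scatter of two such steps. This shows that in this series a step seen on one core cannot simply be transferred to another, but with a single pair on each core it does not show which difference between the two cores matters, or what the change would do on any further core.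

The compounds shown leave open whether the step on the core of compound 3 follows from the nitro group itself or from the loss of the bromine and the methyl group, as all of these change together. They also leave open how a group such as 2-aminophenyl or 2-carboxyphenyl on the amide-type nitrogen would behave on either core.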